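The compounds below may be only part of what the source reports. "The series", "measured", "known", "first", "only" and "open" are said of these compounds alone.

Compounds measured so far in an ADME assay on Vero cells (Chlorocebus sabaeus) for cytotoxicity, read by MTT assay, with a stated time of 72 h; on this read-out lower numbers stand for higher toxicity in this test and higher numbers for lower toxicity in this test:

Compound 1 `O=c1nc(N2CCN(NCC3CCCC3)CC2)sc2c([N+](=O)[O-])cc(C(F)(F)F)cc12` gives > 64 ug/mL, a limit of the assay rather than a number.
Compound 2 `CON=C1CCC(N(C)N2CCN(c3nc(=O)c4cc(C(F)(F)F)cc([N+](=O)[O-])c4s3)CC2)CC1` gives > 64 ug/mL, again a limit of the assay.
Compound 3 `O=c1nc(N2CCN(NCc3ccc(F)cc3)CC2)sc2c([N+](=O)[O-])cc(C(F)(F)F)cc12` gives > 64 ug/mL, also a limit of the assay.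

Compound 3 stands at the same limit as the other two, so that (the limit of > 64 ug/mL in this assay, at which 3 of the 3 values shown sit). No order among the three can be read from this, and each of the steps a step that the two limits leave unreadable from compound 1 to compound 2, a step that the two limits leave unreadable from compound 1 to compound 3 and a step that the two limits leave unreadable from compound 2 to compound 3 is of a size the limits do not reveal. Compound 4 `COc1ccc(CNN2CCN(c3nc(=O)c4cc(C(F)(F)F)cc([N+](=O)[O-])c4s3)CC2)cc1` differs from compound 3 in one place: methoxy in place of fluoro on an aromatic carbon. The measured steps bear on this only in that changes at the same amine nitrogen, far larger than this one, left every value at the limit. The expectation for the step that the limit leaves unreadable from compound 3 to compound 4 in this assay is therefore no reading beyond the scatter. Compound 4 is accordingly estimated at 90 ug/mL, within 40 ug/mL to 250 ug/mL, most likely again reported as a limit.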

Compound 4, half-maximal cytotoxic concentration: > 64 ug/mL
Compound 4 ended at the assay's limit; the forecaster's own chance of this, stated with the estimate: 85%; the middle value does not contradict the limit.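

In this assay, for the compounds shown here, no step among compound 1, compound 2, compound 3 and compound 4 can be read, since all four values are limits of the assay: the limit of > 64 ug/mL in this assay, at which 4 of the 4 values shown sit.

The compounds shown leave open how far any of the four lies beyond that limit, and whether the changes at the amine nitrogen or on the aromatic ring differ at all in their effect on this read-out.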